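Nitro in Place of Methoxy: an Expected Cytotoxicity Reading

This account rests on a few compounds, and the source may have more. Where it says the series, first, only, none or still open, it means among the compounds named here.

Of the compounds shown here, two have been measured in an ADME assay on L02 cells (Homo sapiens) for cytotoxicity, read by MTT assay, with a stated time of 48 h; a lower number here means a stronger inhibitor, a higher number a weaker inhibitor. Compound 1 `Fc1ccc2nc(-c3cccc(-c4nc5ccc(F)cc5[nH]4)c3)[nH]c2c1` gives 20800 nM in this assay. Compound 2 `COc1cc(-c2nc3ccc([N+](=O)[O-])cc3[nH]2)cc(-c2nc3ccc([N+](=O)[O-])cc3[nH]2)c1` gives 26300 nM in this assay, and the two numbers lie within the usual scatter of each other, so neither compound can be called more or less cytotoxic than the other on this evidence. Compound 3 `O=[N+]([O-])c1cc(-c2nc3ccc([N+](=O)[O-])cc3[nH]2)cc(-c2nc3ccc([N+](=O)[O-])cc3[nH]2)c1` has not yet been measured. It differs from compound 2 in one place: nitro in place of methoxy on an aromatic carbon. Going by the values given here, no measured pair in this set shares that same change, so there is no observed step to draw on. Among the compounds with values here, the only guide is that both measured compounds, which differ in several places at once, land close together, which suggests that a single substituent swap on the central ring need not move the number far. For compound 3 the expected step of a 1.2-fold lower number from compound 2 to compound 3 (0.08 log units; within the scatter) is therefore none beyond the scatter. Compound 3 is estimated to give 22000 nM in this assay, with a range from 9000 nM to 50000 nM.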

Compound 3, half-maximal inhibitory concentration: 44900 nM
Estimate against measurement, compound 3: 2.0-fold (0.31 log units) below, and the stated range covers the measured number.
By their numbers in this assay, from the lowest: compounds 1, 2 and 3 (each within the scatter of the next, the first and the last beyond it).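

In this assay, going by these compounds alone, placing nitro in place of methoxy on this aromatic carbon, meta to two large groups, gives a 1.7-fold higher number from compound 2 to compound 3 (0.23 log units; within the scatter) and is the first observed step for this change at this position. The earlier compounds shown here differed in several places at once, so they could only hint at what a single swap here might do, whereas this pair isolates one substituent while the rest of the molecule stays the same. Since the step lies within the scatter, methoxy and nitro cannot be told apart at this position in this cytotoxicity measurement, and no measurement shown here explains the size of the step.

From the compounds shown here alone, whether an amine, a carboxylic acid or a longer chain such as propoxy on this same carbon would also stay within the scatter of compound 2 remains open. Going by these compounds, this change is also seen only once, on a single shared core, so it is unknown whether nitro in place of methoxy would give a similar step on a different core.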